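This account rests on a few compounds, and the source may have more. Where it says the series, first, only, none or still open, it means among the compounds named here.

In a functional assay on HT-29 cells (Homo sapiens) for inhibition, read by sulforhodamine B assay, with a stated time of 48 h (on this read-out lower numbers stand for stronger inhibition of growth and higher numbers for weaker inhibition of growth), compound 3 (`O=C(CCl)NC(=O)Nc1ccc(-c2ccccc2)cc1`) gives 2300 nM, level with compound 2 (`O=C(CCl)NC(=O)Nc1ccc(C2CCCCC2)cc1`) at 2300 nM. Together they hold the lowest number so far, and compound 1 (`c1cc(OC2CCCC2)ccc1NC1=NCCO1`) stands higher at 16100 nM. Compound 4 (`O=C(CCl)NC(=O)Nc1ccc(OC2CCCC2)cc1`) departs from compound 3 in one place: cyclopentyloxy in place of phenyl on an aromatic carbon. Going by the values given here, the only measured step at this place, no change at the digits printed from compound 2 to compound 3 (within the scatter), exchanged cyclohexyl for phenyl. Among the compounds with values here, no measured step tests cyclopentyloxy on this core, and compound 1 carries that group on a different core, so it gives only weak guidance. The expected step is small, a 1.2-fold higher number from compound 3 to compound 4 (0.09 log units; within the scatter), with no change beyond the scatter anticipated. For compound 4 the estimated value is 2800 nM, with an expected range of 1200 nM to 6500 nM.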

Compound 4, concentration for 50% growth inhibition: 3100 nM
Beside the measured number, compound 4's estimate is 1.1-fold (0.04 log units) below it, and the stated range covers the measured number.
By their numbers in this assay, from the lowest: compounds 2, 3 and 4 (each within the scatter of the next); then compound 1.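

In this assay the oxygen-linked cyclopentyloxy group, with its hydrogen-bond acceptor and non-aromatic five-membered ring, gives a 1.3-fold higher number from compound 3 to compound 4 (0.13 log units; within the scatter) and a 1.3-fold higher number from compound 2 to compound 4 (0.13 log units; within the scatter). On the shared core, this position therefore shows no separation beyond the scatter among phenyl, cyclohexyl and cyclopentyloxy. Nothing available accounts for this result.

As far as these compounds go, whether an amine, a carboxylic acid or a longer alkyl chain at this position would give a step beyond the scatter remains open. Also open, from the compounds shown here alone, is how cyclopentyloxy compares with phenyl or cyclohexyl on the core of compound 1.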